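A few compounds are considered here, and "the series" means these few. Any claim that something is new, unique, unknown or untested is made for them only; others in the source may bear on it.

Working notes on the series. Compound 1 `CC(C)C[C@H](N)c1cc(C(F)(F)F)ccc1N1CCN(C(=O)[C@H]2CS(=O)(=O)C[C@@H]2c2ccc(Cl)cc2)CC1` carries a free amine and gives 38 nM in an assay on HEK293 cells for displacement of a labelled ligand from Melanocortin receptor 4 (Homo sapiens); on this read-out higher numbers stand for weaker inhibition and lower numbers for stronger inhibition. Compound 2 `CC(C)C[C@H](NCCN(C)C)c1cc(C(F)(F)F)ccc1N1CCN(C(=O)[C@H]2CS(=O)(=O)C[C@@H]2c2ccc(Cl)cc2)CC1` gives 170 nM in this assay, and compound 3 `CNCCC(=O)N[C@@H](CC(C)C)c1cc(C(F)(F)F)ccc1N1CCN(C(=O)[C@H]2CS(=O)(=O)C[C@@H]2c2ccc(Cl)cc2)CC1` gives 190 nM. Of the three numbers compound 3 stands highest, but it sits close to compound 2, the pair being within the scatter, while the gap to compound 1 is beyond it. The two substitutions on the amine nitrogen move in the same direction: a 4.5-fold higher number from compound 1 to compound 2 (0.65 log units; beyond the scatter) and a 5.0-fold higher number from compound 1 to compound 3 (0.70 log units; beyond the scatter), whereas a 1.1-fold higher number from compound 2 to compound 3 (0.05 log units; within the scatter) shows no separation.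

Compound 4 `CN[C@H](C)C(=O)N[C@@H](CC(C)C)c1cc(C(F)(F)F)ccc1N1CCN(C(=O)[C@H]2CS(=O)(=O)C[C@@H]2c2ccc(Cl)cc2)CC1` is the next step. It differs from compound 3 only in the arrangement of the same atoms: 1-(methylamino)ethyl in place of 2-(methylamino)ethyl on a carbonyl carbon. Going by the values given here, no measured pair bears directly on such a rearrangement of the chain on a carbonyl carbon; the only informative steps concern adding a chain to the amine nitrogen, which is already present in both compound 3 and compound 4. With nothing to suggest a shift, the expectation for compound 4 is a step of no change at the digits printed from compound 3 to compound 4 (within the scatter), that is, a number within the scatter of compound 3. The estimate for compound 4 in this assay is 190 nM, with an expected range from 80 nM to 450 nM.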

Compound 4, inhibition constant: 100 nM
Compound 4: the middle estimate sits 1.9-fold (0.28 log units) above what was measured; the range from low to high includes it.
By their numbers in this assay, from the lowest: compound 1; then compounds 4, 2 and 3 (each within the scatter of the next).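

Replacing 2-(methylamino)ethyl with 1-(methylamino)ethyl on a carbonyl carbon, which keeps the same atoms and adds a defined stereocentre, gives a 1.9-fold lower number from compound 3 to compound 4 (0.28 log units; within the scatter), so in this assay this rearrangement of the chain does not separate the two compounds. Compound 4 is likewise not separated from the amine-linked chain of compound 2, with a 1.7-fold lower number from compound 2 to compound 4 (0.23 log units; within the scatter), yet it remains apart from the free amine, with a 2.6-fold higher number from compound 1 to compound 4 (0.42 log units; beyond the scatter), so all three substituents shown on the amine nitrogen now stand beyond the scatter of compound 1. No independent data bear on why these numbers fall as they do.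

The compounds shown leave open how the opposite configuration at the new stereocentre would read. They also leave open whether a primary amine in place of the methylamino group, or a longer chain on the carbonyl carbon, would come closer to compound 1.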